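Adding One Methoxy to a Dimethoxy Styryl Compound

The source may hold more compounds than are shown below. What is called first, only, known or untested is meant among the compounds shown, and "the series" means these compounds.

Compound 1 `COc1ccc(/C=C/C2(C)C=CC(=O)O2)c(OC)c1`: 151000 nM
Compound 2 `COc1ccc(/C=C/C2(C)C=CC(=O)O2)c(OC)c1OC`: 349000 nM
Compound 3 `COc1cc(OC)c(OC)cc1/C=C/C1(C)C=CC(=O)O1`: 158000 nM

These values come from a functional assay on NCI/ADR-RES cells (Homo sapiens) for inhibition, read by sulforhodamine B assay, with a stated time of 48 h; on this read-out higher numbers stand for weaker inhibition of growth and lower numbers for stronger inhibition of growth. Compound 1 stands at the low end of the three numbers, together with compound 3, and the gap between them is a 1.0-fold higher number from compound 1 to compound 3 (0.02 log units; within the scatter).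

Compound 4 `COc1cc(OC)c(/C=C/C2(C)C=CC(=O)O2)c(OC)c1`, not yet measured, carries one change from compound 1: methoxy in place of hydrogen on an aromatic carbon, a methoxy in place of hydrogen on an aromatic carbon.

Going by the values given here, two measured steps make the same kind of swap, each at a different aromatic carbon from the one changed in compound 4. So they guide the expectation without settling it. One is a 2.3-fold higher number from compound 1 to compound 2 (0.36 log units; beyond the scatter), and the other is the small gap to compound 3 given above. The expected size therefore lies between these two steps, with the number moving upward, towards weaker inhibition of growth. The estimated step is a 1.5-fold higher number from compound 1 to compound 4 (0.16 log units; within the scatter). For compound 4 the expected value is 220000 nM, with an estimated range of 120000 nM to 400000 nM.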

Compound 4, concentration for total growth inhibition: 229000 nM
The estimate for compound 4 lay 1.0-fold (0.02 log units) below the measured number; the range from low to high includes it.
By their numbers in this assay, from the lowest: compounds 1, 3, 4 and 2 (each within the scatter of the next, the first and the last beyond it).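

In this assay, a methoxy placed ortho to a group of 9 heavy atoms and meta to two methoxy groups gives a 1.5-fold higher number from compound 1 to compound 4 (0.18 log units; within the scatter), so the read-out does not separate this swap from ordinary scatter. The same kind of swap at another aromatic carbon gives a 2.3-fold higher number from compound 1 to compound 2 (0.36 log units; beyond the scatter), so adding a methoxy does not have the same outcome at every aromatic carbon, with compound 2 going beyond the scatter while compound 3 and compound 4 stay within it. No measurement shown here explains this difference between positions.

On these data alone, at this position, only hydrogen and methoxy can be compared, so the outcome with an amine, a carboxylic acid or a longer chain such as butoxy remains open. As far as these compounds go, whether the same picture holds on a different core or in other cells also remains open.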